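The source may report more compounds than this note shows. Statements on the series, on what has been measured and on what is new or still open speak of the compounds shown alone.

Of the compounds shown here, three on a shared core have been measured so far in a functional assay on MDA-MB-231 cells (Homo sapiens) for antiproliferative activity, with a stated time of 4 days (on this read-out higher numbers stand for weaker inhibition and lower numbers for stronger inhibition), on this read-out. Compound 1 (`CCCCc1ccc2[nH]c(-c3ccc(OC)cc3)c(C=O)c2c1`) gives 6.7 nM and compound 2 (`CCCCCc1ccc2[nH]c(-c3ccc(OC)cc3)c(C=O)c2c1`) gives 5.5 nM in the same test. Compound 3 (`CCCCc1ccc2[nH]c(-c3ccc(C(F)(F)F)cc3)c(C=O)c2c1`) gives 33 nM and carries the highest number of the three. Compound 4 (`CCCCCc1ccc2[nH]c(-c3ccc(C(F)(F)F)cc3)c(C=O)c2c1`) has not yet been measured. It differs from compound 3 by methyl in place of hydrogen on a saturated chain carbon, four bonds along the chain from an aromatic carbon (propyl to butyl, read one bond further out). The same change has been measured once, in the methoxy pair, as a 1.2-fold lower number from compound 1 to compound 2 (0.09 log units; within the scatter) and so stayed within the scatter. The other measured step, a 4.9-fold higher number from compound 1 to compound 3 (0.69 log units; beyond the scatter) in the trifluoromethyl exchange, sets the level from which compound 4 starts but does not touch the chain. Whether the chain change behaves alike with trifluoromethyl in place has not been tested. The step expected here is a 1.2-fold lower number from compound 3 to compound 4 (0.07 log units; within the scatter) and lies within the scatter. Compound 4 is estimated at 28 nM (14 nM to 55 nM).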

Compound 4, half-maximal inhibitory concentration: 42 nM
The estimate for compound 4 lay 1.5-fold (0.18 log units) below the measured number, within the range that was stated.
By their numbers in this assay, from the lowest: compounds 2 and 1 (each within the scatter of the next); then compounds 3 and 4 (each within the scatter of the next).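

In this assay the chain change now has a second reading, and with trifluoromethyl in place it gives a 1.3-fold higher number from compound 3 to compound 4 (0.10 log units; within the scatter) and stays as small as it was with methoxy: the same change on two cores in this assay, a 1.2-fold lower number (0.09 log units; within the scatter) from compound 1 to compound 2 and a 1.3-fold higher number (0.10 log units; within the scatter) from compound 3 to compound 4, 1.6-fold (0.19 log units) apart, within the scatter of two such steps. Within the data shown here, the trifluoromethyl exchange, read for the first time on the other chain, gives a 7.6-fold higher number from compound 2 to compound 4 (0.88 log units; beyond the scatter) and remains beyond the scatter with either chain: the same change on two cores in this assay, a 4.9-fold higher number (0.69 log units; beyond the scatter) from compound 1 to compound 3 and a 7.6-fold higher number (0.88 log units; beyond the scatter) from compound 2 to compound 4, 1.6-fold (0.19 log units) apart, within the scatter of two such steps. Across these four compounds, the level of the number follows the exchange of methoxy for trifluoromethyl and not the added methyl.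

The compounds shown leave open whether the chain position stays this flat for a longer chain such as hexyl, or for an amine or a carboxylic acid on the chain. They also leave open how a nitrile or a chlorine would compare with methoxy and trifluoromethyl.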